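From amino to diethylamino: what to expect

This account rests on a few compounds, and the source may have more. Where it says the series, first, only, none or still open, it means among the compounds named here.

In a functional assay on the whole organism with Rattus norvegicus as the target (a lower number here means that less compound is needed, a higher number that more compound is needed for the effect), compound 1 `CCOC(=O)C(=O)Nc1cccc(N)c1C#N` gives 0.07 mg/kg, the lowest of the numbers in hand. Compound 3 `CCCNc1cccc(NC(=O)C(=O)OCC)c1C#N` comes nearest, at 0.7 mg/kg. Compound 2 `CCOC(=O)C(=O)Nc1cc(N(C)C)ccc1C#N` reaches only a limit of the assay, > 100 mg/kg.

Compound 4 `CCOC(=O)C(=O)Nc1cccc(N(CC)CC)c1C#N` has diethylamino in place of amino on an aromatic carbon of compound 1 (diethylamino in place of amino on an aromatic carbon). Within the data shown here, the one measured step that bears on this is a 10-fold higher number from compound 1 to compound 3 (1.00 log units; beyond the scatter), which lies beyond the scatter and puts propyl in place of hydrogen on a nitrogen on an aromatic ring. Diethylamino is a change of a similar kind, so a step of similar size or somewhat more, towards a higher number, is expected: a 29-fold higher number from compound 1 to compound 4 (1.46 log units; beyond the scatter). For compound 4 the estimated value is 2 mg/kg, with an expected range of 0.3 mg/kg to 20 mg/kg.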

Compound 4, dose for half-maximal effect: 0.9 mg/kg
Compound 4: the middle estimate sits 2.2-fold (0.35 log units) above what was measured; low and high end bracket the measured number.
By their numbers in this assay, from the lowest: compound 1; then compounds 3 and 4 (each within the scatter of the next). At a limit, above all of these: compound 2.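

The step to diethylamino, a 13-fold higher number from compound 1 to compound 4 (1.11 log units; beyond the scatter), is a real loss, yet this position, ortho to a cyano group, still tolerates a group of 5 heavy atoms with 0 hydrogen-bond donors. The further comparison, a 1.3-fold higher number from compound 3 to compound 4 (0.11 log units; within the scatter), lies within the scatter, so propylamino and diethylamino cannot be told apart here. Any substituent tested on this nitrogen has so far cost about the same.

Going by these compounds, whether a longer chain, such as dibutylamino, would follow the same pattern remains open. Nothing in hand gives a reason for these steps.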